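Removing the 4-methylphenyl from compound 2

A few compounds are considered here, and "the series" means these few. Any claim that something is new, unique, unknown or untested is made for them only; others in the source may bear on it.

In a functional assay on HeLa cells (Homo sapiens) for cytotoxicity, read by MTT assay, with a stated time of 72 h (a higher number here means a weaker inhibitor, a lower number a stronger inhibitor), compound 1 `Cc1ccc(-c2ccnc(Nc3ccc(F)cc3)c2)cc1` gives 146000 nM. Compound 2 `COc1ccc(Nc2cc(-c3ccc(C)cc3)ccn2)cc1` gives 43000 nM, the lower of the two actual numbers. Compound 3 `CCc1ccc(Nc2cc(-c3cccc(C(F)(F)F)c3)ccn2)cc1` reaches only a limit of the assay, > 200000 nM. Compound 4 `COc1ccc(Nc2ccccn2)cc1` is made from compound 2 by a single change: hydrogen in place of 4-methylphenyl on an aromatic carbon, so hydrogen stands in place of 4-methylphenyl. Within the data shown here, no measured step makes this change. The nearest guide is a 3.4-fold lower number from compound 1 to compound 2 (0.53 log units; beyond the scatter), a modest step made at a different place, and it leaves the 4-methylphenyl untouched. A modest step towards a higher number, meaning a weaker inhibitor, is therefore expected, though this is uncertain. The estimated change is a 2.3-fold higher number from compound 2 to compound 4 (0.37 log units; beyond the scatter). For compound 4 the expected value is 100000 nM, with an estimated range from 35000 nM to 200000 nM.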

Compound 4, half-maximal inhibitory concentration: 117000 nM
Beside the measured number, compound 4's estimate is 1.2-fold (0.07 log units) below it; measured number inside the range.
By their numbers in this assay, from the lowest: compound 2; then compounds 4 and 1 (each within the scatter of the next). At a limit, above all of these: compound 3.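

In this assay, among these compounds, this is the first step that changes the group opposite the ring nitrogen, and removing the 4-methylphenyl gives a weaker inhibitor: a 2.7-fold higher number from compound 2 to compound 4 (0.43 log units; beyond the scatter). The group therefore contributes to the number, yet compound 4 still gives a real value without it, not a limit. Only compound 3 stands at a limit: the limit of > 200000 nM in this assay, at which 1 of the 4 values shown sits.

As far as these compounds go, whether an amine, a carboxylic acid or a longer chain at this position would give a stronger inhibitor remains open. So does whether the step would be the same with fluoro in place of methoxy.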